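This account rests on a few compounds, and the source may have more. Where it says the series, first, only, none or still open, it means among the compounds named here.

In a functional assay on the whole organism (strain Wistar) for inhibition, with Rattus norvegicus as the target, read by paw edema, with a stated time of 30 min, at a dose of 10 mg/kg by the intraperitoneal route (on this read-out lower numbers stand for less inhibition and higher numbers for more inhibition at the one dose given (going by the name of the read-out)), compound 2 `O=C(N/N=C/c1cccc(O)c1)c1cccnc1Nc1cccc(C(F)(F)F)c1` gives 67.5%, the highest of the two numbers measured, while compound 1 `O=C(N/N=C/c1ccc(Cl)cc1)c1cccnc1Nc1cccc(C(F)(F)F)c1` gives 52.4%. Among the measured compounds shown here, compound 3 `O=C(N/N=C/c1ccc(O)cc1)c1cccnc1Nc1cccc(C(F)(F)F)c1` has not yet been measured. 4-hydroxyphenyl in place of 3-hydroxyphenyl on a carbon with a double bond to nitrogen The only measured step, a number 15.1 percentage points higher from compound 1 to compound 2 (beyond the scatter), exchanged a whole different group at this carbon, so no step directly shows what moving the hydroxyl from one ring position to another does; the size of that change is unknown here. Compound 3 is therefore expected to differ from compound 2 by a number 3.5 percentage points lower from compound 2 to compound 3 (within the scatter), within the scatter. The estimate for compound 3 is 64%, with a range from 48% to 80%.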

Compound 3, a percentage reported as inhibition, in the whole organism at one dose (the size of the read-out at that dose, not a potency): 59.3%
For compound 3 the middle estimate is 4.7 percentage points above the measured one; low and high end bracket the measured number.
By their numbers in this assay, from the lowest: compounds 1, 3 and 2 (each within the scatter of the next, the first and the last beyond it).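

In this assay, moving the hydroxyl on the ring gives a number 8.2 percentage points lower from compound 2 to compound 3 (within the scatter) and so does not separate 4-hydroxyphenyl from 3-hydroxyphenyl at this carbon. Hydroxy in place of chloro on an aromatic carbon gives a number 6.9 percentage points higher from compound 1 to compound 3 (within the scatter) and so is also not separated from the scatter, although the 3-hydroxyphenyl of compound 2 stands beyond the scatter of compound 1. Nothing available explains these numbers. Still open, from the compounds shown here alone, is whether an amine or a carboxylic acid on this ring would shift the number beyond the scatter.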